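This account rests on a few compounds, and the source may have more. Where it says the series, first, only, none or still open, it means among the compounds named here.

Compound 1, `COC(=O)/C=C/c1cccc(N(C)C(=O)C2CCCCC2)c1`, gives in an assay on isolated protein with Bile acid receptor (Homo sapiens) as the target (on this read-out lower numbers stand for an effect already at smaller amounts and higher numbers for an effect only at larger amounts of compound), a value of > 1000 nM, which is a limit of the assay and not a number.
Compound 2, `COC(=O)/C=C/c1cccc(N(Cc2cccc(Br)c2)C(=O)C2CCCCC2)c1`, gives in this assay > 1000 nM, again a limit rather than a measured number.
Compound 3, `COC(=O)/C=C/c1cccc(N(Cc2ccc(Br)cc2)C(=O)C2CCCCC2)c1`, gives in this assay > 1000 nM, likewise only a limit.

Compound 3 thus stands at the limit of the assay, and every value shown shares that position (the limit of > 1000 nM in this assay, at which 3 of the 3 values shown sit). The steps between the measured compounds cannot be sized: a step that the two limits leave unreadable from compound 1 to compound 2, a step that the two limits leave unreadable from compound 1 to compound 3 and a step that the two limits leave unreadable from compound 2 to compound 3 all remain unreadable, each end of each step being a limit. All that can be said is that exchanging hydrogen for a 3-bromophenyl or a 4-bromophenyl group on the saturated chain carbon bound to the amide-type nitrogen did not bring any compound below the limit.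

Compound 4, `COC(=O)/C=C/c1cccc(N(Cc2cccc(OC)c2)C(=O)C2CCCCC2)c1`, differs from compound 3 in one place: 3-methoxyphenyl in place of 4-bromophenyl on a saturated chain carbon bound to an amide-type nitrogen. For the measured compounds named here, no measured step covers this change, and none has a readable size, so the expected step that the limit leaves unreadable from compound 3 to compound 4 rests on no measured direction and is assumed to lie within scatter of an unreadable limit. Compound 4 is therefore estimated at 3000 nM, within a range from 600 nM to 30000 nM, with the assay most likely again reporting only a limit.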

Compound 4, half-maximal effective concentration: > 1000 nM
Compound 4 was reported as a limit; the forecaster's own chance of this, stated with the estimate: 80%; the middle value lies beyond the limit too.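

Compound 4, like compound 1, compound 2 and compound 3, reaches only a limit in this assay and not a number, so no step among these compounds can be read: the limit of > 1000 nM in this assay, at which 4 of the 4 values shown sit.

The compounds shown leave open how far each one lies beyond that limit, and whether any other group at this place would give a measurable value.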